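The source may report more compounds than this note shows. Statements on the series, on what has been measured and on what is new or still open speak of the compounds shown alone.

Measured so far:
compound 1 `CN(C)CCCNc1ccc2c(c1)sc1cc(C#N)c3nc4ccccc4n3c12` — 1.03
compound 2 `N#Cc1c(N2CCCCC2)c2sc3cc(N4CCCCC4)ccc3c2n2c1nc1ccccc12` — "not determined" (no result reported) in a physicochemical assay for lipophilicity, read by HPLC, at pH 2.7; a lower number here means a more polar compound, a higher number a more lipophilic compound
compound 3 `CC(C)CNc1c(C#N)c2nc3ccccc3n2c2c1sc1ccccc12` — 4.67

The account follows the step from compound 1 to compound 4 `N#Cc1cc2sc3cc(N4CCNCC4)ccc3c2n2c1nc1ccccc12`. Among the two numbers that exist, compound 1 stands lowest: compound 1 gives 1.03 and compound 3 gives 4.67, a gap beyond the usual scatter of this assay. Compound 2 adds a third structure but no number, so it cannot place compound 1 any further.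

Compound 4 differs from compound 1 in a single place, (piperazin-1-yl in place of (3-(dimethylamino)propyl)amino on an aromatic carbon). Among the compounds with values here, no pair of measured compounds shows this exact exchange, so the step has no measured counterpart to lean on. Because compound 1 gives 1.03 and the exchanged groups are close in what is counted, the step is expected to be small, with no direction claimed beyond the scatter. The estimated step from compound 1 to compound 4 in this assay is a number 0.17 log units higher from compound 1 to compound 4 (within the scatter). Compound 4 is therefore expected to give 1.2, within the range 0.4 to 2.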

Compound 4, distribution coefficient: 0.84
For compound 4 the middle estimate is 0.36 log units above the measured one; measured number inside the range.
By their numbers in this assay, from the lowest: compounds 4 and 1 (each within the scatter of the next); then compound 3.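

Within the data shown here, the earlier compounds offered no pair differing in one place, so this is the first direct reading at this aromatic carbon. In this assay, piperazin-1-yl in place of (3-(dimethylamino)propyl)amino gives a number 0.19 log units lower from compound 1 to compound 4 (within the scatter), so this read-out does not separate the open chain from the six-membered non-aromatic ring on the core of compound 1. Nothing measured on these compounds offers an explanation for this result.

As far as these compounds go, whether the same holds for other groups at this carbon remains open, for example a morpholine ring, a carboxylic acid or a longer chain ending in an amine. A single step also leaves open whether this exchange would give a similar result on any other core.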